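The compounds below may be only part of what the source reports. "The series", "measured", "known", "first", "only" and "open" are said of these compounds alone.

Series so far, in a functional assay on OVCAR-3 cells (Homo sapiens) for antiproliferative activity, read by MTT assay, with a stated time of 24 h; on this read-out lower numbers stand for stronger inhibition and higher numbers for weaker inhibition:
- compound 1 `O=C(NNc1ccccc1F)c1ccccc1NS(=O)(=O)c1cnc(O)nc1O`: 9570 nM
- compound 2 `O=C(NNc1ccc(F)cc1)c1ccccc1NS(=O)(=O)c1cnc(O)nc1O`: > 20000 nM (a limit of the assay, not a number)
- compound 3 `O=C(NNC(=O)c1ccccc1NS(=O)(=O)c1cnc(O)nc1O)c1ccccc1F`: 15300 nM

Compound 3 stands level with compound 1 within the scatter, a 1.6-fold higher number from compound 1 to compound 3 (0.20 log units; within the scatter). Next is compound 4 `O=C(NNC(=O)c1ccccc1NS(=O)(=O)c1cnc(O)nc1O)c1ccc(F)cc1`: 4-fluorophenyl in place of 2-fluorophenyl on a carbonyl carbon. For the measured compounds named here, the closest precedent is the same exchange on an amine nitrogen, an at least 2.0-fold higher number from compound 1 to compound 2 (0.32 log units; beyond the scatter), a step known only as a floor, given (the limit of > 20000 nM in this assay, at which 1 of the 3 values shown sits). Going by the values given here, no measured step covers the exchange on the carbonyl carbon itself. On that single precedent, a modest move to a higher number is expected in this assay, and a report of only a limit is possible. The estimated step is a 1.4-fold higher number from compound 3 to compound 4 (0.16 log units; within the scatter). Compound 4 is expected at 22000 nM, with an estimated range of 11000 nM to 45000 nM.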

Compound 4, half-maximal inhibitory concentration: 15100 nM
The estimate for compound 4 lay 1.5-fold (0.16 log units) above the measured number; low and high end bracket the measured number.
By their numbers in this assay, from the lowest: compounds 1, 4 and 3 (each within the scatter of the next). At a limit, above all of these: compound 2.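

In this assay, 4-fluorophenyl in place of 2-fluorophenyl on a carbonyl carbon gives a 1.0-fold lower number from compound 3 to compound 4 (0.01 log units; within the scatter), so the exchange that gave an at least 2.0-fold higher number from compound 1 to compound 2 (0.32 log units; beyond the scatter) on an amine nitrogen does not carry over to this place. Placing (4-fluorophenyl)carbonyl on the amine nitrogen instead of 2-fluorophenyl gives a 1.6-fold higher number from compound 1 to compound 4 (0.20 log units; within the scatter), so this change also stays within the scatter. The remaining pair offers only a floor, an at least 1.3-fold lower number from compound 2 to compound 4 (0.12 log units; that floor lies within the scatter), set by a limit of the assay and not a number: the limit of > 20000 nM in this assay, at which 1 of the 4 values shown sits.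

Still open, on these data alone, is whether a chlorophenyl or methoxyphenyl group in place of the fluorophenyl groups would move the number beyond the scatter.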